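The source may hold more compounds than are shown below. What is called first, only, known or untested is meant among the compounds shown, and "the series" means these compounds.

Measured so far:
compound 1 `Cc1cnc(Nc2ccc(C#N)cc2)nc1Nc1c(F)cc(-c2cncc(C(F)(F)F)c2)cc1F`: 8200 nM
compound 2 `Cc1cc(-c2cc3ccccc3s2)cc(C)c1Nc1ccnc(Nc2ccc(C#N)cc2)n1`: 138000 nM

In a toxicity assay on MT4 cells (Homo sapiens) for cytotoxicity, read by MTT assay, with a stated time of 5 days (a higher number here means that more compound is tolerated, a lower number that less compound is tolerated), compound 2 gives 138000 nM, the higher of the two numbers. Compound 1 gives 8200 nM. The gap between these two compounds lies beyond the scatter. Compound 3 `Cc1cc(-c2cc(C)c(Nc3ccnc(Nc4ccc(C#N)cc4)n3)c(C)c2)ccn1` follows from compound 2 by one change, 2-methylpyridin-4-yl in place of 1-benzothiophen-2-yl on an aromatic carbon. For the measured compounds named here, the two measured compounds differ in more than one place, so no measured step gauges this change. With compound 2 at the top of a very small range at 138000 nM, a move towards a lower number, beyond the scatter, is expected: a 3.5-fold lower number from compound 2 to compound 3 (0.54 log units; beyond the scatter). For compound 3 the estimated value is 40000 nM, with an expected range of 9000 nM to 180000 nM.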

Compound 3, half-maximal cytotoxic concentration: 4900 nM
Compound 3: middle estimate off by 8.2-fold (0.91 log units), on the high side; measured number below the stated range.
By their numbers in this assay, from the lowest: compounds 3 and 1 (each within the scatter of the next); then compound 2.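

In this assay, the group on this aromatic carbon, para to a large group, strongly shifts the read-out: 2-methylpyridin-4-yl in place of 1-benzothiophen-2-yl gives a 28-fold lower number from compound 2 to compound 3 (1.45 log units; beyond the scatter). This first readable step at the position shows that the tolerated concentration is not set by the shared core alone. No accompanying measurement speaks to the origin of this step. The compounds shown leave open whether the step tracks the ring nitrogen or the methyl of 2-methylpyridin-4-yl. A phenyl or an unsubstituted pyridin-4-yl at this place would separate the two.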